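The source may report more compounds than this note shows. Statements on the series, on what has been measured and on what is new or still open speak of the compounds shown alone.

Three compounds of the series have so far been run in a functional assay on MCF7 cells (Homo sapiens) for inhibition, read by sulforhodamine B assay, with a stated time of 72 h; on this read-out higher numbers stand for weaker inhibition of growth and lower numbers for stronger inhibition of growth. Compound 3 `O=C(O)CCc1ccncc1-c1ccc2ccccc2c1` reaches only the assay limit, giving > 10000 nM in this assay. Compound 1 `CNC(=O)CCc1ccncc1-c1ccc2ccccc2c1` likewise returns only the limit > 10000 nM in this assay. The step from compound 3 to compound 1 is a step that the two limits leave unreadable from compound 3 to compound 1; the change made is methylamino in place of hydroxy on a carbonyl carbon. Compound 2 `Cn1ccc2cc(-c3cnccc3/C=C/C(=O)O)ccc21` also gives only the limit > 10000 nM in this assay. The difference between the core of compound 2 and the core of compound 3 is not broken down here.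

Compound 4 `CNC(=O)/C=C/c1ccncc1-c1ccc2c(ccn2C)c1` carries the same kind of change relative to compound 2, namely (methylamino in place of hydroxy on a carbonyl carbon); the place differs in that the carbonyl carbon's other neighbour is a double-bonded chain carbon rather than a saturated chain carbon. With the limit of > 10000 nM in this assay, at which 3 of the 3 values shown sit, the step from compound 3 to compound 1 was unreadable, and the estimated step from compound 2 to compound 4 is a step that the limit leaves unreadable from compound 2 to compound 4. Compound 4 is expected to give 15000 nM in this assay, with a result reported only as a limit thought most likely.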

Compound 4, concentration for 50% growth inhibition: 7120 nM
Compound 4: middle estimate off by 2.1-fold (0.32 log units), on the high side, and the stated range ends above it.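

In this assay, methylamino in place of hydroxy on a carbonyl carbon whose other neighbour is a double-bonded chain carbon gives an at least 1.4-fold lower number from compound 2 to compound 4 (0.14 log units; that floor lies within the scatter), so this step alone does not establish a real gain. Going by these compounds, its full size also stays unknown, as compound 2 is only a limit. The same change in the other core, from compound 3 to compound 1, cannot be read, so no carry-over between cores is shown, in either direction: the limit of > 10000 nM in this assay, at which 3 of the 4 values shown sit.

Open, on these data alone, is how the change behaves with the saturated chain on the core of compound 2, or the double-bonded chain on the core of compound 3. Also open, as far as these compounds go, is how dimethylamino or a longer chain on the amide nitrogen would compare with methylamino.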